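From Chloro to Bromo on the Shared Core

This account rests on a few compounds, and the source may have more. Where it says the series, first, only, none or still open, it means among the compounds named here.

Measured so far:
compound 1, `CC1(Cc2ccccc2)OS(=O)(=O)C=C1OCc1ccccc1`: 68000 nM
compound 2, `CCC1(Cc2ccccc2)OS(=O)(=O)C=C1OCc1ccc(Cl)cc1`: > 200000 nM

Both compounds were tested in an ADME assay on HEL cells (Homo sapiens) for cytotoxicity, with a stated time of 3 days; a higher number here means that more compound is tolerated, a lower number that less compound is tolerated. Compound 1 gives 68000 nM there. Compound 2 gives > 200000 nM, which is a limit of the assay and not a number; it stands at the limit of > 200000 nM in this assay, at which 1 of the 2 values shown sits. Where compound 2 stands is therefore known only as that limit, and its tolerated concentration is not pinned down further.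

Compound 3, `CCC1(Cc2ccccc2)OS(=O)(=O)C=C1OCc1ccc(Br)cc1`, is not yet measured. It differs from compound 2 in one place: bromo in place of chloro on an aromatic carbon. For the measured compounds named here, no step between two measured compounds is available to size this change, so no shift beyond the scatter is expected in either direction. In this assay the expected step is a number no higher from compound 2 to compound 3 (the limit leaves the size open), small either way. Compound 3 is accordingly estimated at 200000 nM, within 100000 nM to 400000 nM, and the assay may well report only a limit again.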

Compound 3, half-maximal cytotoxic concentration: 171000 nM
Estimate against measurement, compound 3: 1.2-fold (0.07 log units) above; the measured number falls inside the stated range.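

With bromo in place of chloro on the aromatic carbon, this assay shows an at least 1.1-fold lower number from compound 2 to compound 3 (0.06 log units; that floor lies within the scatter). For the compounds shown here, compound 3 gives a measured number, 171000 nM, so this position on the shared core now has a firm reading for cell tolerance, which the earlier compounds did not provide. Compound 2 itself remains at a limit of the assay, not a number: the limit of > 200000 nM in this assay, at which 1 of the 3 values shown sits.

From the compounds shown here alone, how far the step reaches beyond its floor stays unknown, and compound 1 differs from compound 3 in more than one place, so it cannot size this change. Chloro and bromo also say nothing about how a different group in this place, such as an amine, a carboxylic acid or a longer chain, would be tolerated.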